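The source may report more compounds than this note shows. Statements on the series, on what has been measured and on what is new or still open speak of the compounds shown alone.

Of the compounds shown here, three sharing one core have numbers so far in a functional assay on P388 cells (Mus musculus) for antiproliferative activity (a higher number here means a weaker inhibitor, a lower number a stronger inhibitor), and all three sit close together. Compound 1 (`COc1ccc(S(=O)(=O)Nc2cccc3c(Cl)c[nH]c23)cc1`) reads 0.76 ug/mL there, compound 2 (`NC(=O)c1ccc(S(=O)(=O)Nc2cccc3c(Cl)c[nH]c23)cc1`) reads 0.87 ug/mL there, and compound 3 (`Nc1ccc(S(=O)(=O)Nc2cccc3c(Cl)c[nH]c23)cc1`) reads 0.81 ug/mL there. Compound 3 thus stands within the scatter of both others, and the three cannot be ranked. Compound 4 (`CS(=O)(=O)Nc1ccc(S(=O)(=O)Nc2cccc3c(Cl)c[nH]c23)cc1`) departs from compound 3 by methylsulfonyl in place of hydrogen on a nitrogen on an aromatic ring in one place, with methylsulfonyl in place of hydrogen on a nitrogen on an aromatic ring, so that amino becomes methanesulfonamido.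

The measured steps that bear on this are exchanges of the same group on an aromatic carbon. Amino in place of methoxy gave a 1.1-fold higher number from compound 1 to compound 3 (0.03 log units; within the scatter) and amino in place of carbamoyl gave a 1.1-fold lower number from compound 2 to compound 3 (0.03 log units; within the scatter) while carbamoyl in place of methoxy gave a 1.1-fold higher number from compound 1 to compound 2 (0.06 log units; within the scatter) in turn. On the strength of these three small steps, no change beyond the scatter is expected in this assay in either direction. Among the compounds with values here, none of the measured compounds carries methylsulfonyl, however, so the range is kept wide. The expected step is a 1.0-fold lower number from compound 3 to compound 4 (0.01 log units; within the scatter) by this estimate. Compound 4 is estimated at 0.8 ug/mL with an expected range from 0.4 ug/mL to 1.7 ug/mL in this measurement.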

Compound 4, half-maximal inhibitory concentration: 1.6 ug/mL
For compound 4 the middle estimate is 2.0-fold (0.30 log units) below the measured one; the measured number falls inside the stated range.
By their numbers in this assay, from the lowest: compounds 1, 3, 2 and 4 (each within the scatter of the next, the first and the last beyond it).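

In this assay, methylsulfonyl in place of hydrogen on a nitrogen on an aromatic ring gave a 2.0-fold higher number from compound 3 to compound 4 (0.30 log units; within the scatter), and methanesulfonamido in place of carbamoyl gave a 1.8-fold higher number from compound 2 to compound 4 (0.26 log units; within the scatter), so neither of these steps can be told from noise. Methanesulfonamido in place of methoxy gave a 2.1-fold higher number from compound 1 to compound 4 (0.32 log units; beyond the scatter), a modest step but the only one in the series that clears the scatter, so the position is no longer entirely flat across the groups shown, although that holds for this one pair alone. No measured data are at hand to explain this step.

The compounds shown leave open whether the sulfonyl unit itself matters here or whether any group on this nitrogen would give a similar number, a question that acetyl on the same nitrogen or a longer chain such as ethylsulfonyl would address. They also leave open how a carboxylic acid or a dimethylamino group on the same aromatic carbon would read, and whether anything at this position can move the number well beyond the scatter.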